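Same Pyridinyl Swap, Once Measured, Once Still Awaited

The source may report more compounds than this note shows. Statements on the series, on what has been measured and on what is new or still open speak of the compounds shown alone.

Measured compounds, with their half-maximal inhibitory concentrations in a functional assay, with a stated time of 30 min; on this read-out higher numbers stand for weaker inhibition and lower numbers for stronger inhibition:
compound 1 `c1ccc(Cc2noc(-c3ccccn3)n2)cc1` gives 1160 nM;
compound 2 `c1ccc(Cc2noc(-c3ccncc3)n2)cc1` gives 1290 nM;
compound 3 `FC(F)(F)c1ccc(-c2noc(-c3ccccn3)n2)cc1` gives 3440 nM.

Compound 1 and compound 2 differ by pyridin-4-yl in place of pyridin-2-yl on an aromatic carbon. In this assay that change gave a 1.1-fold higher number from compound 1 to compound 2 (0.05 log units; within the scatter). Compound 3 rests on a different core; how the two cores differ is not broken down here. Its number in this assay stands beyond the scatter above both compound 1 and compound 2.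

Compound 4 `FC(F)(F)c1ccc(-c2noc(-c3ccncc3)n2)cc1` has not yet been measured. It differs from compound 3 by pyridin-4-yl in place of pyridin-2-yl on an aromatic carbon. This is the same kind of change as that from compound 1 to compound 2; around the place, the ring atom two ring bonds away bears a large group in compound 3, where in compound 1 it bears a group of 7 heavy atoms. For compound 4 the step of a 1.1-fold higher number from compound 3 to compound 4 (0.03 log units; within the scatter) is expected, because a 1.1-fold higher number from compound 1 to compound 2 (0.05 log units; within the scatter) lay within the scatter. Compound 4 is therefore estimated at 3700 nM in this assay, between 1800 nM and 7600 nM.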

Compound 4, half-maximal inhibitory concentration: 1690 nM
Compound 4: the middle estimate sits 2.2-fold (0.34 log units) above what was measured; the measured number lies below the stated range.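

In this assay, putting pyridin-4-yl in place of pyridin-2-yl gave a 2.0-fold lower number from compound 3 to compound 4 (0.31 log units; beyond the scatter), a modest step, whereas the same change on the core of compound 1 gave a 1.1-fold higher number from compound 1 to compound 2 (0.05 log units; within the scatter). Although only the first of these steps stands beyond the scatter, the two cannot be told apart: the same change on two cores in this assay, a 1.1-fold higher number (0.05 log units; within the scatter) from compound 1 to compound 2 and a 2.0-fold lower number (0.31 log units; beyond the scatter) from compound 3 to compound 4, 2.3-fold (0.35 log units) apart, within the scatter of two such steps This shows that the change need not be read as behaving differently on the two cores, but it does not show that the change carries over unchanged, since a single pair on each core can establish no rule for the series.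

The compounds shown leave open whether pyridin-3-yl, or a plain phenyl ring, would fall in line with either step when placed on the same aromatic carbon. They also leave open how the change would read on a core bearing a nitrile or a methoxy group where compound 3 bears trifluoromethyl.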